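From propargyl to 2-fluorobenzyl on the shared core

A few compounds are considered here, and "the series" means these few. Any claim that something is new, unique, unknown or untested is made for them only; others in the source may bear on it.

Values measured in a functional assay on HUVEC cells (Homo sapiens) for antiproliferative activity, read by MTT assay, with a stated time of 24 h (on this read-out lower numbers stand for stronger inhibition and higher numbers for weaker inhibition), stand as follows

Compound 1 `C=CCOc1ccc2c(=O)c(-c3cc(OC)c(OC)cc3OC)coc2c1` gives > 10000 nM as a limit
Compound 2 `C#CCOc1ccc2c(=O)c(-c3cc(OC)c(OC)cc3OC)coc2c1` gives > 10000 nM as a limit
Compound 3 `COc1cc(OC)c(-c2coc3cc(OCc4ccccc4)ccc3c2=O)cc1OC` gives 9750 nM as a number

In this assay compound 2 gives > 10000 nM and this is a limit, not a number. Compound 2 therefore sits at the limit of > 10000 nM in this assay, at which 2 of the 3 values shown sit, and no exact position can be read for it.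

Compound 4 `COc1cc(OC)c(-c2coc3cc(OCc4ccccc4F)ccc3c2=O)cc1OC` has not yet been measured. It puts 2-fluorophenyl in place of ethynyl on a saturated chain carbon bound to an oxygen on an aromatic ring, a change counted as 2-fluorophenyl in place of ethynyl on a saturated chain carbon bound to an oxygen on an aromatic ring and read one bond further out as propargyl to 2-fluorobenzyl.

The closest measured change is an at least 1.0-fold lower number from compound 2 to compound 3 (0.01 log units; that floor lies within the scatter) with phenyl in place of ethynyl at that same place. The matching replacement of vinyl shows an at least 1.0-fold lower number from compound 1 to compound 3 (0.01 log units; that floor lies within the scatter) and adds no further size. The exchange of vinyl and ethynyl gives a step that the two limits leave unreadable from compound 1 to compound 2 and offers no guide. Among the compounds with values here, no measured compound carries fluorine.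

Compound 3 at 9750 nM is the only basis for expecting a modest move toward a lower number. The step expected in this assay is an at least 1.2-fold lower number from compound 2 to compound 4 (0.09 log units; that floor lies within the scatter) and it points in that direction. For compound 4 the estimated value is 8000 nM with 3000 nM to 15000 nM as the expected range.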

Compound 4, half-maximal inhibitory concentration: 4300 nM
For compound 4 the middle estimate is 1.9-fold (0.27 log units) above the measured one; the range from low to high includes it.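

In this assay, within the data shown here, the swap of fluoro in place of hydrogen on an aromatic carbon gives the only step at this place with both a readable size and a position beyond the scatter: it is a 2.3-fold lower number from compound 3 to compound 4 (0.36 log units; beyond the scatter) (the earlier steps offered only floors within the scatter). With 2-fluorophenyl on the saturated chain carbon, the series now also shows an at least 2.3-fold lower number from compound 2 to compound 4 (0.36 log units; beyond the scatter) and an at least 2.3-fold lower number from compound 1 to compound 4 (0.36 log units; beyond the scatter) (phenyl alone did not clear the scatter against ethynyl or vinyl). Both of these steps are floors and not sizes, since compound 1 and compound 2 each rest on a limit and not on a number, and compound 2 stands thus: (the limit of > 10000 nM in this assay, at which 2 of the 4 values shown sit).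

The compounds shown leave open whether chloro, methoxy or a nitrile in place of that fluoro would move the number the same way, and whether fluoro elsewhere on the phenyl ring would match 2-fluorobenzyl. They also leave open what an amine, a carboxylic acid or a longer chain at this place on the shared core would do in this assay and how far below compound 3 such a change could go.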